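A few compounds are considered here, and "the series" means these few. Any claim that something is new, unique, unknown or untested is made for them only; others in the source may bear on it.

Measured in an in vitro ADME assay on microsomes from liver (Homo sapiens) for metabolic stability; a lower number here means slower removal, a higher number faster removal of the compound:
- Compound 1 `COCc1ccccc1C1CCc2nc[nH]c2C1`: < 7 mL.min-1.g-1; < 7 mL.min-1.g-1 (2 entries), a limit of the assay and not a number
- Compound 2 `COc1ccc(C2Cc3nccn3C2)cc1`: 30 mL.min-1.g-1

Going by the values given here, compound 2 holds the only actual number in this short series. Compound 3 `Clc1ccc(C2Cc3nccn3C2)cc1` has chloro in place of methoxy on an aromatic carbon of compound 2 (chloro in place of methoxy on an aromatic carbon). Among the compounds with values here, no measured step informs this change, so the expectation is tentative. A modest fall in this assay is expected, with the estimated step being a 2.0-fold lower number from compound 2 to compound 3 (0.30 log units; within the scatter). The estimate for compound 3 is 15 mL.min-1.g-1, with an expected range from 7 mL.min-1.g-1 to 35 mL.min-1.g-1.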

Compound 3, intrinsic clearance in microsomes: 32 mL.min-1.g-1
Beside the measured number, compound 3's estimate is 2.1-fold (0.33 log units) below it; measured number inside the range.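

In this assay, chloro in place of methoxy on an aromatic carbon, para to a group of 8 heavy atoms, gives a 1.1-fold higher number from compound 2 to compound 3 (0.03 log units; within the scatter). Going by these compounds alone, this is the first readable step, and at this position intrinsic clearance in microsomes does not separate the two groups. No measurement shown bears on why the two groups read alike. Still open, going by these compounds, is whether an amine or a carboxylic acid on this carbon would shift intrinsic clearance beyond the scatter. Also open, on these data alone, is whether the same exchange reads alike on the core of compound 1.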